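This account rests on a few compounds, and the source may have more. Where it says the series, first, only, none or still open, it means among the compounds named here.

Working notes on the series around compound 1 (`Oc1ccc(CN(Cc2ccccc2)Cc2ccc(O)c3ncccc23)c2cccnc12`), tested throughout in a functional assay on U-87MG ATCC cells (Homo sapiens) for antiproliferative activity, with a stated time of 3 days; on this read-out lower numbers stand for an effect already at smaller amounts and higher numbers for an effect only at larger amounts of compound. Compound 1 gives < 0.5 uM as its result, and that is a limit of the assay, not a number. Compound 2 (`Oc1ccc(CN(Cc2cccc(C(F)(F)F)c2)Cc2ccc(O)c3ncccc23)c2cccnc12`) gives 2 uM as a true number. For the measured compounds named here, the only measured step is an at least 4.0-fold higher number from compound 1 to compound 2 (0.60 log units; beyond the scatter) and it rests on that limit, so its real size may be larger. Going by the values given here, compound 3 (`Oc1ccc(CN(Cc2ccc(OC(F)(F)F)cc2)Cc2ccc(O)c3ncccc23)c2cccnc12`) has no place on this scale: its entry reads "not determined" (no result reported) and no step can start from it.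

Compound 4 (`Oc1ccc(CN(Cc2cccc(I)c2)Cc2ccc(O)c3ncccc23)c2cccnc12`) differs from compound 3 as follows: 3-iodophenyl in place of 4-(trifluoromethoxy)phenyl on a saturated chain carbon bound to an amine nitrogen that is, 3-iodophenyl in place of 4-(trifluoromethoxy)phenyl on a saturated chain carbon bound to an amine nitrogen. No size can be stated for the change from compound 3. The nearest guide is compound 2, which, like compound 4, carries a group in place of hydrogen on the aromatic ring left bare in compound 1. Measured from compound 1, a step of similar size and the same direction, towards a higher number, is therefore expected in this assay for compound 4, though a result at the limit remains possible. The estimate for compound 4 is 1.5 uM as the expected value, with an expected range of 0.5 uM to 5 uM for the measurement.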

Compound 4, concentration for half-maximal effect: 2 uM
The estimate for compound 4 lay 1.3-fold (0.12 log units) below the measured number; measured number inside the range.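

In this assay, iodo in place of trifluoromethyl on an aromatic carbon gives no change at the digits printed from compound 2 to compound 4 (within the scatter), so at this level of reading the two groups cannot be told apart. Iodo in place of hydrogen on an aromatic carbon gives an at least 4.0-fold higher number from compound 1 to compound 4 (0.60 log units; beyond the scatter), which runs in the same direction as the earlier step, an at least 4.0-fold higher number from compound 1 to compound 2 (0.60 log units; beyond the scatter), so within compounds 1, 2 and 4 the rise no longer rests on trifluoromethyl alone. Compound 1 stands at a limit and not at a number, and both of these steps start from it, so neither has a known full size: the limit of < 0.5 uM in this assay, at which 1 of the 4 values shown sits.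

Steps from compound 3 cannot be read, which leaves 4-(trifluoromethoxy)phenyl unplaced against 3-iodophenyl. As far as these compounds go, it also stays open whether an amine, a carboxylic acid or a methoxy group on this aromatic ring would give the same higher number as iodo and trifluoromethyl, or a result closer to that of compound 1.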